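Swapping Bromo for Isopropoxy at the End of a Shared Core

The compounds below may be only part of what the source reports. "The series", "measured", "known", "first", "only" and "open" are said of these compounds alone.

Three compounds share one core and differ only in a single group on the aromatic ring at one end. Compound 1 `O=C(CCCC1CCN(Cc2ccccc2)CC1)c1ncco1` carries that ring unsubstituted; in an assay on isolated protein for inhibition of Fatty-acid amide hydrolase 1 (Homo sapiens) (on this read-out lower numbers stand for stronger inhibition and higher numbers for weaker inhibition), compound 1 gives 315 nM. Compound 2 `COc1cccc(CN2CCC(CCCC(=O)c3ncco3)CC2)c1` adds a methoxy group, and compound 2 gives 34 nM. Compound 3 `O=C(CCCC1CCN(Cc2cccc(Br)c2)CC1)c1ncco1` carries a bromo group instead, and compound 3 gives 10 nM, the lowest of the three numbers. The measured steps are a 9.3-fold lower number from compound 1 to compound 2 (0.97 log units; beyond the scatter), a 32-fold lower number from compound 1 to compound 3 (1.50 log units; beyond the scatter) and a 3.4-fold lower number from compound 2 to compound 3 (0.53 log units; beyond the scatter).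

Compound 4 `CC(C)Oc1cccc(CN2CCC(CCCC(=O)c3ncco3)CC2)c1` is the next one to be measured: isopropoxy in place of bromo on an aromatic carbon. The step from compound 2 to compound 3 bears most directly on it, since isopropoxy, like the methoxy of compound 2, brings one hydrogen-bond acceptor, while the bromo of compound 3 brings none. Giving back part of that modest gain, compound 4 is expected to show a 2.0-fold higher number from compound 3 to compound 4 (0.30 log units; within the scatter). Compound 4 is therefore estimated at 20 nM, with a range from 5 nM to 80 nM.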

Compound 4, half-maximal inhibitory concentration: 5 nM
Beside the measured number, compound 4's estimate is 4.0-fold (0.60 log units) above it; measured number inside the range.
By their numbers in this assay, from the lowest: compounds 4 and 3 (each within the scatter of the next); then compound 2; then compound 1.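

Isopropoxy brings the largest gain seen at this position in this assay, with a 63-fold lower number from compound 1 to compound 4 (1.80 log units; beyond the scatter) on the unsubstituted ring, and replacing the methyl on the oxygen with isopropyl gives a 6.8-fold lower number from compound 2 to compound 4 (0.83 log units; beyond the scatter), so the group attached to that oxygen clearly affects the result. Bromo and isopropoxy, however, are not separated by this assay: a 2.0-fold lower number from compound 3 to compound 4 (0.30 log units; within the scatter) stays within the scatter, even though isopropoxy has a hydrogen-bond acceptor and more heavy atoms while bromo has neither. No supporting measurement is available to explain why these groups give the numbers they do.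

The compounds shown leave open how the series responds to ethoxy or a longer chain on the same oxygen. They also do not show whether an amine or a carboxylic acid could be tolerated at this position.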